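Swapping the Ring on the Thiocarbonyl Carbon

The source may report more compounds than this note shows. Statements on the series, on what has been measured and on what is new or still open speak of the compounds shown alone.

Of the compounds shown here, three sharing a thiosemicarbazide-type chain have been tested in a functional assay on A-375 cells (Homo sapiens) for cytotoxicity, read by MTT assay, with a stated time of 72 h, tested at 10 uM; a lower number here means less inhibition of growth, a higher number more inhibition of growth at the concentration tested. Compound 1 `Cc1cccc(/C(N)=N/NC(=S)N2CCCCC2)n1` gives 76.4%. Compound 2 `Cc1cccc(/C(N)=N/NC(=S)N2CCCC2)n1` gives 55.9%. Compound 3 `Cc1ccnc(/C(N)=N/NC(=S)N2CCCCC2)c1` gives 81.2%. Compound 3 and compound 1 are built from the same atoms joined differently; the difference between the two cores is not broken down here, and their numbers lie within the scatter of each other. Between compound 1 and compound 2 the change is pyrrolidin-1-yl in place of piperidin-1-yl on a thiocarbonyl carbon and it brought a number 20.5 percentage points lower from compound 1 to compound 2 (beyond the scatter). Compound 4 `Cc1ccnc(/C(N)=N/NC(=S)N2CCCC2)c1` is not yet measured; it differs from compound 3 by pyrrolidin-1-yl in place of piperidin-1-yl on a thiocarbonyl carbon, the same change at the same place. Because compound 1 to compound 2 showed a number 20.5 percentage points lower from compound 1 to compound 2 (beyond the scatter), a similar fall is expected for compound 4, namely a number 19.2 percentage points lower from compound 3 to compound 4 (beyond the scatter). The estimate for compound 4 is therefore 62%, expected to lie between 47% and 77%.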

Compound 4, percent growth inhibition at one concentration: 86%
Estimate against measurement, compound 4: 24 percentage points below; measured number above the stated range.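

In this assay, putting pyrrolidin-1-yl in place of piperidin-1-yl on the core of compound 3 gave a number 4.8 percentage points higher from compound 3 to compound 4 (within the scatter), so the clear fall seen on the core of compound 1 did not carry over. The same change therefore cannot be assumed to do the same thing on both cores: the same change on two cores in this assay, a number 20.5 percentage points lower (beyond the scatter) from compound 1 to compound 2 and a number 4.8 percentage points higher (within the scatter) from compound 3 to compound 4, 25.3 percentage points apart, beyond the scatter of two such steps. This does not show why the two cores differ, and two pairs of compounds give no rule for predicting the change on any further core.

The compounds shown leave open how other groups on the thiocarbonyl carbon would behave on these two cores. A morpholine ring or a dimethylamino group would be examples.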